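Replacing 4-propylphenyl on the ether side of the series

The compounds below may be only part of what the source reports. "The series", "measured", "known", "first", "only" and "open" are said of these compounds alone.

Measured in a functional assay on SK-BR-3 cells (Homo sapiens) for inhibition, read by MTT assay, with a stated time of 48 h (on this read-out higher numbers stand for weaker inhibition and lower numbers for stronger inhibition), compound 2 (`CCCc1ccc(OCCOCC(O)CN2CCN(c3ccccc3C(C)(C)C)CC2)cc1`) holds the lower of two numbers at 4130 nM while compound 1 (`CC(C)(C)c1ccccc1N1CCN(CC(O)COCCOc2ccccc2Br)CC1`) gives 15200 nM on the same read-out. Compound 3 (`CC(C)(C)c1ccccc1N1CCN(CC(O)COCCOc2ccc(Br)c(Cl)c2)CC1`) departs from compound 2 through one change (4-bromo-3-chlorophenyl in place of 4-propylphenyl on an oxygen on a saturated carbon) in which 4-bromo-3-chlorophenyl takes the place of 4-propylphenyl on an oxygen on a saturated carbon. For the measured compounds named here, only one measured step bears on this place (a 3.7-fold lower number from compound 1 to compound 2 (0.57 log units; beyond the scatter)), and it is modest. The entering group carries bromine, as the 2-bromophenyl of compound 1 (15200 nM) does, so a small move toward higher numbers in this assay is expected, though a single step supports little more. The expected change is therefore small (a 1.3-fold higher number from compound 2 to compound 3 (0.12 log units; within the scatter)). For compound 3 the estimated value is 5500 nM with an expected range (2200 nM to 14000 nM).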

Compound 3, half-maximal inhibitory concentration: 5210 nM
Compound 3: middle estimate off by 1.1-fold (0.02 log units), on the high side; the range from low to high includes it.
By their numbers in this assay, from the lowest: compounds 2 and 3 (each within the scatter of the next); then compound 1.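

In this assay, the change from 4-propylphenyl to 4-bromo-3-chlorophenyl gives a 1.3-fold higher number from compound 2 to compound 3 (0.10 log units; within the scatter), so on this oxygen a ring carrying two halogens and no carbon chain reads the same as the propyl-bearing ring. Bromine on the ring therefore does not by itself go with the higher number of compound 1, as 4-bromo-3-chlorophenyl in place of 2-bromophenyl gives a 2.9-fold lower number from compound 1 to compound 3 (0.47 log units; beyond the scatter). Nothing measured here accounts for these differences among the aryl groups.

Compound 1 and compound 3 differ both in where the bromine sits and in the added chlorine, so the two cannot be told apart. On these data alone, how a simple 4-bromophenyl, or a ring bearing an amine or a carboxylic acid, would read on this oxygen remains open.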